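Chloro-to-hydrogen step carried over to a second core

This account rests on a few compounds, and the source may have more. Where it says the series, first, only, none or still open, it means among the compounds named here.

Compound 1 `O=C1C2=C(C(=O)c3ncccc31)C1(CS2)NC(=O)N(c2ccc(Cl)cc2)C1=O` gives 590 nM in a functional assay on XF498 cells (Homo sapiens) for antiproliferative activity, read by MTT assay, with a stated time of 96 h; on this read-out lower numbers stand for stronger inhibition and higher numbers for weaker inhibition. Compound 2 `O=C1C2=C(C(=O)c3ncccc31)C1(CS2)NC(=O)N(c2ccccc2)C1=O` differs from it by hydrogen in place of chloro on an aromatic carbon and gives 1510 nM in this assay, so that a 2.6-fold higher number from compound 1 to compound 2 (0.41 log units; beyond the scatter). Compound 3 `O=C1NN(c2ccc(Cl)cc2)C(=O)C2(CSC3=C2C(=O)c2ncccc2C3=O)N1` sits on a second core; the difference between the two cores is not broken down here. In this assay compound 3 gives 2500 nM. Compound 4 `O=C1NN(c2ccccc2)C(=O)C2(CSC3=C2C(=O)c2ncccc2C3=O)N1` is not yet measured and differs from compound 3 by hydrogen in place of chloro on an aromatic carbon, the same change as between compound 1 and compound 2, with the same surroundings of the place. A step of about the same size as a 2.6-fold higher number from compound 1 to compound 2 (0.41 log units; beyond the scatter) is expected, a 2.4-fold higher number from compound 3 to compound 4 (0.38 log units; beyond the scatter), resting on that single pair. For compound 4 in this assay a value of 6000 nM is expected, within 2500 nM to 15000 nM.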

Compound 4, half-maximal inhibitory concentration: 4550 nM
Estimate against measurement, compound 4: 1.3-fold (0.12 log units) above; the range from low to high includes it.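

In this assay, the change from 4-chlorophenyl to phenyl on the second core gives a 1.8-fold higher number from compound 3 to compound 4 (0.26 log units; within the scatter), so this step alone does not stand clear of repeat measurements. Set beside the step on the first core, the change carries over with no detectable difference in size: the same change on two cores in this assay, a 2.6-fold higher number (0.41 log units; beyond the scatter) from compound 1 to compound 2 and a 1.8-fold higher number (0.26 log units; within the scatter) from compound 3 to compound 4, 1.4-fold (0.15 log units) apart, within the scatter of two such steps. With one pair on each core and a single cell line, this shows agreement for this one change, not a general rule for moving substituents between cores in the series.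

From the compounds shown here alone, only chloro and hydrogen appear at this place, so the effect of a methoxy group, an amine or a carboxylic acid there remains open on both cores. Going by these compounds, whether the step would hold on a third core also remains open.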